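Peak plasma exposure across one side-chain change

A few compounds are considered here, and "the series" means these few. Any claim that something is new, unique, unknown or untested is made for them only; others in the source may bear on it.

In an in vivo ADME assay on the whole organism (plasma) for pharmacokinetics, with Rattus norvegicus as the target, at a dose of 50 mg/kg by the oral route (on this read-out lower numbers stand for lower exposure and higher numbers for higher exposure at the dose given), compound 1 `Cc1cc(C)c(NC(=O)c2sccc2S(=O)(=O)Nc2onc(C)c2Cl)c(C(=O)C2CC2)c1` gives 108000 nM, compound 2 `Cc1cc(C)c(NC(=O)c2sccc2S(=O)(=O)Nc2onc(C)c2Cl)c(C(=O)c2ccccc2)c1` gives 63100 nM and compound 3 `Cc1cc(C)c(NC(=O)c2sccc2S(=O)(=O)Nc2onc(C)c2Cl)c(C(=O)CS(C)(=O)=O)c1` gives 68300 nM. Compound 3 therefore lies within the usual scatter of both other compounds. Compound 4 `CO/N=C(\C)c1cc(C)cc(C)c1NC(=O)c1sccc1S(=O)(=O)Nc1onc(C)c1Cl` differs from it in one place: a group of 5 heavy atoms (3 carbon, 1 nitrogen, 1 oxygen; no ring) in place of a group of 7 heavy atoms (3 carbon, 3 oxygen, 1 sulfur; no ring), on an aromatic carbon. The measured steps that bear on this change only swap the group on the carbonyl carbon: a 1.7-fold lower number from compound 1 to compound 2 (0.23 log units; within the scatter), a 1.6-fold lower number from compound 1 to compound 3 (0.20 log units; within the scatter) and a 1.1-fold higher number from compound 2 to compound 3 (0.03 log units; within the scatter). All three lie within the scatter, but none of them replaces the carbonyl itself, so the guidance is indirect. In this assay no step beyond the scatter is expected, and the estimated change is a 1.1-fold higher number from compound 3 to compound 4 (0.04 log units; within the scatter). The estimated value for compound 4 is 75000 nM, with an expected range of 30000 nM to 165000 nM.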

Compound 4, maximal plasma concentration: 27800 nM
Estimate against measurement, compound 4: 2.7-fold (0.43 log units) above; the measured number lies below the stated range.
By their numbers in this assay, from the lowest: compound 4; then compounds 2, 3 and 1 (each within the scatter of the next).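

In this assay, replacing the carbonyl itself on this aromatic carbon gives steps beyond the scatter, which no swap on the carbonyl carbon did: a 2.5-fold lower number from compound 3 to compound 4 (0.39 log units; beyond the scatter), a 2.3-fold lower number from compound 2 to compound 4 (0.36 log units; beyond the scatter) and a 3.9-fold lower number from compound 1 to compound 4 (0.59 log units; beyond the scatter). The three carbonyl compounds, whichever group they carry, thus all stand apart from compound 4, whose entering group of 5 heavy atoms has no carbonyl. Nothing available here accounts for the drop. The compounds shown leave open whether losing the carbonyl alone lowers the number or the rest of the entering group does. They also leave open how an amine or a carboxylic acid on the same aromatic carbon would read.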